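A few compounds are considered here, and "the series" means these few. Any claim that something is new, unique, unknown or untested is made for them only; others in the source may bear on it.

Compound 1 `C=Cc1cccc(-c2[nH]c3cc(OC)ccc3c(=O)c2C(=O)OCC)c1`: > 21500 nM (a limit)
Compound 2 `CCOC(=O)c1c(-c2cccc([N+](=O)[O-])c2)[nH]c2cc(OC)ccc2c1=O`: > 21500 nM (a limit)
Compound 3 `CCOC(=O)c1c(-c2cccc(N(C)C)c2)[nH]c2cc(OC)ccc2c1=O`: > 21500 nM (a limit)

In an ADME assay on Raji cells (Homo sapiens) for cytotoxicity, read by luminescence, with a stated time of 72 h (on this read-out lower numbers stand for an effect already at smaller amounts and higher numbers for an effect only at larger amounts of compound), compound 3 gives > 21500 nM, which is a limit and not a number. The whole series offers only the limit of > 21500 nM in this assay, at which 3 of the 3 values shown sit, and no readable value. Compound 4 `CCOC(=O)c1c(-c2cccc(NC(C)=O)c2)[nH]c2cc(OC)ccc2c1=O` carries acetamido in place of dimethylamino on an aromatic carbon. For the measured compounds named here, three measured steps concern that same carbon: a step that the two limits leave unreadable from compound 1 to compound 2, a step that the two limits leave unreadable from compound 1 to compound 3 and a step that the two limits leave unreadable from compound 2 to compound 3. None of them yields a size. Resting on a step that the two limits leave unreadable from compound 2 to compound 3, no step beyond the scatter is expected in this assay, and the estimate amounts to a step that the limit leaves unreadable from compound 3 to compound 4 as the expected change. Compound 4 is estimated at 30000 nM, with an expected range from 12000 nM to 80000 nM.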

Compound 4, half-maximal effective concentration: > 21500 nM
Compound 4: no number, only a limit (the forecaster's own chance of this, stated with the estimate: 85%); the middle value is on the limit's open side.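

No new step can be read: compound 4, like compound 1, compound 2 and compound 3, gives only a limit in this assay. The compounds shown leave open whether any of these groups changes the value, because the whole series rests on one limit: the limit of > 21500 nM in this assay, at which 4 of the 4 values shown sit.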